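Enantiomer switch at the chain stereocentre, compound 2 to 3

The source may report more compounds than this note shows. Statements on the series, on what has been measured and on what is new or still open speak of the compounds shown alone.

Measured so far:
compound 1, `Cc1c(OCCCCOc2ccc(Cl)c(C(=O)O)c2)ccc(C(=O)CC(C)(C)C)c1O`: 130 nM
compound 2, `COc1ccc(C(=O)O)cc1OC[C@H](C)Oc1ccc(C(=O)CC(C)(C)C)c(O)c1C`: 3820 nM

Of the compounds shown here, two have been measured in an assay for positive allosteric modulation of metabotropic glutamate receptor 3 (Rattus norvegicus); on this read-out higher numbers stand for an effect only at larger amounts of compound and lower numbers for an effect already at smaller amounts. Compound 1 gives 130 nM in this assay, and compound 2 gives 3820 nM in this assay, which is the higher of the two numbers, lying well beyond the scatter of the method above compound 1.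

Compound 3, `COc1ccc(C(=O)O)cc1OC[C@@H](C)Oc1ccc(C(=O)CC(C)(C)C)c(O)c1C`, is the next compound and has not yet been measured. The change from compound 2 to compound 3 is the two compounds have the same atoms and bonds and differ only in configuration as drawn: 1 of 1 stereo elements differ; a stereocentre at a saturated chain carbon is drawn S in compound 2 and R in compound 3; the two compounds have the same atoms and bonds and differ only in configuration as drawn, one of one stereo elements differing.

Within the data shown here, no measured pair with this kind of change exists in this set, so the size of the step is open. Because compound 2 gives only 3820 nM in this assay, the other configuration at the chain carbon is expected to give a lower number, though a step of any size, or none beyond the scatter, is possible. The step from compound 2 to compound 3 is expected to be a 3.8-fold lower number from compound 2 to compound 3 (0.58 log units; beyond the scatter). Compound 3 is estimated at 1000 nM in this assay, within a range of 150 nM to 6000 nM.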

Compound 3, half-maximal effective concentration: 806 nM
Estimate against measurement, compound 3: 1.2-fold (0.09 log units) above; the measured number falls inside the stated range.
By their numbers in this assay, from the lowest: compound 1; then compound 3; then compound 2.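

In this assay, the stereocentre at the saturated chain carbon proves to matter on its own, with the change from S to R giving a 4.7-fold lower number from compound 2 to compound 3 (0.68 log units; beyond the scatter). Among these compounds, this is the first pair in the set that differs in one place, so it gives the first direct reading of any single change, here with the R configuration carrying the lower number; compound 1 differs from both compounds in more than one place and could not show this. Since no atom or bond changes within the pair, the step can be assigned to configuration at this one carbon alone, because of what separates the two structures: the fact that compounds 2 and 3 differ only in the configuration as drawn.

The compounds shown leave open whether a step of this size and direction would persist with a larger branch at the chain carbon, such as an ethyl group, or with a tetrazole in place of the carboxylic acid. They also give no account of why the R configuration carries the lower number, and this single pair cannot show whether the same preference holds elsewhere in the series.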